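Removing a methyl next to the amino group

The compounds below may be only part of what the source reports. "The series", "measured", "known", "first", "only" and "open" are said of these compounds alone.

Measured so far:
Compound 1 `COc1cc(C2C(C#N)=C(N)Oc3cc(O)ccc32)cc(Br)c1OC` — 130000000 nM
Compound 2 `COc1cc(C2C(C#N)=C(N)Oc3c2ccc(N)c3C)cc(Br)c1OC` — 26000000 nM

In a functional assay on T47D cells (Homo sapiens) for activation (a lower number here means that less compound is needed, a higher number that more compound is needed for the effect), compound 2 gives 26000000 nM, the lower of the two numbers; compound 1 gives 130000000 nM, a gap beyond the scatter. Compound 3 `COc1cc(C2C(C#N)=C(N)Oc3cc(N)ccc32)cc(Br)c1OC` has not been measured. It differs from compound 2 in one way: hydrogen in place of methyl on an aromatic carbon. Going by the values given here, with no measured pair showing this change, the expected step from compound 2 to compound 3 is small, a 1.7-fold higher number from compound 2 to compound 3 (0.24 log units; within the scatter), toward a somewhat higher number. Compound 3 is therefore expected to give about 45000000 nM in this assay, within a range of 12000000 nM to 160000000 nM.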

Compound 3, half-maximal effective concentration: 33000000 nM
The estimate for compound 3 lay 1.4-fold (0.13 log units) above the measured number, and the stated range covers the measured number.
By their numbers in this assay, from the lowest: compounds 2 and 3 (each within the scatter of the next); then compound 1.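

Swapping methyl for hydrogen on this aromatic carbon gives a 1.3-fold higher number from compound 2 to compound 3 (0.10 log units; within the scatter) in this assay, so the methyl makes no clear difference to the number here. Compound 3 also differs from compound 1 in one place, and amino in place of hydroxy gives a 3.9-fold lower number from compound 1 to compound 3 (0.60 log units; beyond the scatter), which places the modest gain at the amino group rather than at the methyl. No supporting data bear on why either step comes out as it does.

From the compounds shown here alone, whether a fluorine or a methoxy group on this carbon would shift the number remains open. So does whether a methylamino group or an amide could do better than the amino group.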